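Lengthening the side chain from compound 3 to compound 4

This account rests on a few compounds, and the source may have more. Where it says the series, first, only, none or still open, it means among the compounds named here.

Going by the values given here, compound 3 `CCCc1cc2ccccc2nc1-c1cc(-c2ccc(C(F)(F)F)cc2)no1` is the only member of this set that gives a number in a functional assay on COLO 205 cells (Homo sapiens) for inhibition, read by MTT assay, with a stated time of 24 h; a higher number here means a weaker inhibitor, a lower number a stronger inhibitor: compound 3 gives 42200 nM. Compound 1 `CCCCc1cc2ccccc2nc1-c1cc(-c2ccccc2)no1` reaches only a limit of the assay, > 100000 nM. Compound 2 `CCCCc1cc2ccccc2nc1-c1cc(-c2ccc(C)cc2)no1` likewise gives only a limit, > 100000 nM. Among the compounds with values here, two of the three values therefore sit at the limit of > 100000 nM in this assay, at which 2 of the 3 values shown sit, and the one step measured between these compounds, a step that the two limits leave unreadable from compound 1 to compound 2, cannot be read because both ends are limits.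

Compound 4 `CCCCc1cc2ccccc2nc1-c1cc(-c2ccc(C(F)(F)F)cc2)no1` differs from compound 3 by methyl in place of hydrogen on a saturated chain carbon, three bonds along the chain from an aromatic carbon. Within the data shown here, none of the measured steps concerns this saturated chain; the only measured step, from compound 1 to compound 2, changes an aromatic position and is unreadable, so there is no measured guide to how a longer chain moves this assay. With nothing to point either way, the expected step from compound 3 to compound 4, a 1.1-fold lower number from compound 3 to compound 4 (0.02 log units; within the scatter), is none beyond the usual scatter. Compound 4 is therefore estimated at 40000 nM in this assay, within a range from 15000 nM to 100000 nM.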

Compound 4, half-maximal inhibitory concentration: 11900 nM
Compound 4: the middle estimate sits 3.4-fold (0.53 log units) above what was measured; measured number below the stated range.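

In this assay the saturated chain has its first readable effect: the change from propyl to butyl brings a 3.5-fold lower number from compound 3 to compound 4 (0.55 log units; beyond the scatter) and shows that this part of the molecule responds to a small change. With butyl held in place, trifluoromethyl on the aromatic carbon brings an at least 8.4-fold lower number from compound 2 to compound 4 (0.92 log units; beyond the scatter) where it replaces methyl and an at least 8.4-fold lower number from compound 1 to compound 4 (0.92 log units; beyond the scatter) where it replaces hydrogen, so the group on that aromatic carbon also counts once compound 4 gives a real number. These last two steps are minimum sizes rather than exact ones, because compound 1 and compound 2 each give only a limit of the assay, not a number: the limit of > 100000 nM in this assay, at which 2 of the 4 values shown sit.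

A single step on the chain cannot tell whether the trend carries on with a longer chain such as pentyl or hexyl or ends at butyl. The compounds shown also leave open how a chain carrying an amine or a carboxylic acid would compare, and how a chlorine or a methoxy group would compare with trifluoromethyl on the aromatic carbon.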